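This account rests on a few compounds, and the source may have more. Where it says the series, first, only, none or still open, it means among the compounds named here.

Compound 1 `Clc1ccc([C@@H]2C[C@@H]3Cc4ccc5ccccc5c4N2O3)cc1`: in an ADME assay on THP-1 cells (Homo sapiens) for cytotoxicity, read by MTT assay, with a stated time of 72 h (on this read-out higher numbers stand for lower toxicity in this test and lower numbers for higher toxicity in this test), compound 1 gives only a limit, > 300000 nM.
Compound 2 `COc1cccc([C@@H]2C[C@@H]3Cc4ccc5ccccc5c4N2O3)c1`: compound 2 gives only a limit, > 300000 nM.
Compound 3 `Cc1cccc([C@@H]2C[C@@H]3Cc4ccc5ccccc5c4N2O3)c1`: compound 3 gives only a limit, > 300000 nM.

Compound 1 thus stands at the limit of > 300000 nM in this assay, at which 3 of the 3 values shown sit, and no number is available for any of the three. For the measured compounds named here, the steps a step that the two limits leave unreadable from compound 1 to compound 2 and a step that the two limits leave unreadable from compound 1 to compound 3 are therefore unreadable; they show only that exchanging the aryl group has not pushed any compound below the limit. Compound 4 `Clc1ccccc1[C@@H]1C[C@@H]2Cc3ccc4ccccc4c3N1O2` differs from compound 1 by 2-chlorophenyl in place of 4-chlorophenyl on a saturated ring carbon. With every measured step unreadable, no step beyond the scatter is expected in this assay. Compound 4 is accordingly estimated at 300000 nM, with a range from 100000 nM to 1000000 nM, and the step of a number no higher from compound 1 to compound 4 (the limit leaves the size open) is expected to be negligible.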

Compound 4, half-maximal cytotoxic concentration: > 300000 nM
Compound 4 ended at the assay's limit; the forecaster's own chance of this, stated with the estimate: 85%; the middle value sits exactly at the limit.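

The steps from compound 1, compound 2 and compound 3 to compound 4 cannot be read, as all four give only a limit in this assay. The compounds shown leave open what any of them would read as an actual number.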